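Removing the ester chain from compound 1

This account rests on a few compounds, and the source may have more. Where it says the series, first, only, none or still open, it means among the compounds named here.

Compound 1 `COC(=O)CCNC(=O)[C@@H]1CC=C(CCC=C(C)C)C[C@H]1c1ccccc1` sits at the limit of an assay on isolated protein for inhibition of Apoptosis regulator Bcl-2 (Homo sapiens), read by fluorescence polarization, with stated times of 5 min and 10 min; on this read-out higher numbers stand for weaker inhibition and lower numbers for stronger inhibition: compound 1 gives > 23000 nM, a limit rather than a number. Its mirror image, compound 2 `COC(=O)CCNC(=O)[C@H]1CC=C(CCC=C(C)C)C[C@@H]1c1ccccc1`, gives 3100 nM, and the step of an at least 7.4-fold lower number from compound 1 to compound 2 (0.87 log units; beyond the scatter) rests on (the fact that compounds 1 and 2 differ only in the configuration as drawn). Compound 3 `CON(C)C(=O)[C@@H]1CC2=C(CCCC2(C)C)C[C@H]1c1ccccc1` also gives only a limit, > 23000 nM. Compound 4 `CC(C)=CCCC1=CC[C@@H](C(N)=O)[C@H](c2ccccc2)C1` keeps the configuration of compound 1 and differs from it by hydrogen in place of 2-(methoxycarbonyl)ethyl on an amide-type nitrogen. Going by the values given here, no measured step touches that change; the only measured step concerns configuration, and the limit of > 23000 nM in this assay, at which 2 of the 3 values shown sit, shows where compound 1 stands. Starting from a limit, the expected step that the limit leaves unreadable from compound 1 to compound 4 is one with no evidence of movement beyond the scatter, so compound 4 is estimated at 30000 nM, between 8000 nM and 110000 nM.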

Compound 4, inhibition constant: > 23000 nM
Compound 4: only a limit was reported; the forecaster's own chance of this, stated with the estimate: 75%; the middle value is on the limit's open side.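

In this assay compound 4 gives > 23000 nM, a limit and not a number. Compound 1 also stands at a limit, and the step between compound 1 and compound 4 cannot be read. The compounds shown leave open whether replacing 2-(methoxycarbonyl)ethyl with hydrogen changes inhibition at all.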